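This account rests on a few compounds, and the source may have more. Where it says the series, first, only, none or still open, it means among the compounds named here.

- Compound 1 `NCCCOc1ccc([C@H]2CC[C@]3(CC2)OOC2(O3)C3CC4CC(C3)CC2C4)cc1`: < 7 mL.min-1.g-1 (a limit, not a number)
- Compound 2 `OC1(COc2ccc([C@H]3CC[C@]4(CC3)OOC3(O4)C4CC5CC(C4)CC3C5)cc2)CCNCC1`: 16 mL.min-1.g-1
- Compound 3 `CS(=O)(=O)N1CCN(CCCOc2ccc([C@H]3CC[C@]4(CC3)OOC3(O4)C4CC5CC(C4)CC3C5)cc2)CC1`: 68 mL.min-1.g-1

In an ADME assay on microsomes from liver (Homo sapiens) for metabolic stability, read by LC-MS, tested at 1 uM (a lower number here means slower removal, a higher number faster removal of the compound), compound 3 stands highest of the values shown, at 68 mL.min-1.g-1. The nearest value belongs to compound 2, at 16 mL.min-1.g-1, and the gap is a 4.3-fold higher number from compound 2 to compound 3 (0.63 log units; beyond the scatter). Compound 1 gives only a limit, not a number.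

The next compound, compound 4 `CC1(C)CC(O)(COc2ccc([C@H]3CC[C@]4(CC3)OOC3(O4)C4CC5CC(C4)CC3C5)cc2)CC(C)(C)N1`, has not yet been measured. Relative to compound 3, it carries 4-hydroxy-2,2,6,6-tetramethylpiperidin-4-yl in place of 2-(4-(methylsulfonyl)piperazin-1-yl)ethyl on a saturated chain carbon bound to an oxygen on an aromatic ring.

The closest guide is a 4.3-fold higher number from compound 2 to compound 3 (0.63 log units; beyond the scatter), read backwards. Going by the values given here, its 4-hydroxypiperidin-4-yl resembles the entering group, although no measured step covers the tetramethyl part. The other two steps, an at least 2.2-fold higher number from compound 1 to compound 2 (0.35 log units; beyond the scatter) and an at least 9.7-fold higher number from compound 1 to compound 3 (0.98 log units; beyond the scatter), both start from a limit and bear less directly.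

Read backwards, a 4.3-fold higher number from compound 2 to compound 3 (0.63 log units; beyond the scatter) points to a fall of similar size in this assay, beyond the scatter, towards slower removal. The expected change is a 3.4-fold lower number from compound 3 to compound 4 (0.53 log units; beyond the scatter). For compound 4 the estimated value is 20 mL.min-1.g-1, with an expected range from 8 mL.min-1.g-1 to 50 mL.min-1.g-1.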

Compound 4, intrinsic clearance in microsomes: 14 mL.min-1.g-1
Estimate against measurement, compound 4: 1.4-fold (0.15 log units) above; low and high end bracket the measured number.
By their numbers in this assay, from the lowest: compounds 4 and 2 (each within the scatter of the next); then compound 3. At a limit, below all of these: compound 1.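

In this assay, the tetramethyl part of 4-hydroxy-2,2,6,6-tetramethylpiperidin-4-yl makes no difference that can be read at this position, since the step is a 1.1-fold lower number from compound 2 to compound 4 (0.06 log units; within the scatter) and the two numbers cannot be told apart. Replacing 2-(4-(methylsulfonyl)piperazin-1-yl)ethyl on the same saturated chain carbon gives a much clearer difference, a 4.9-fold lower number from compound 3 to compound 4 (0.69 log units; beyond the scatter), so compound 3 now stands apart from two compounds that both carry a hydroxypiperidine group. The comparison with compound 1 rests on a limit, not a number, and gives only a floor, an at least 2.0-fold higher number from compound 1 to compound 4 (0.30 log units; that floor lies within the scatter): the limit of < 7 mL.min-1.g-1 in this assay, at which 1 of the 4 values shown sits.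

Compound 3 differs from the hydroxypiperidine compounds in both its ring and its chain, so the compounds shown cannot say which part sets its higher number. From the compounds shown here alone, a piperidin-4-yl without the hydroxy group, or a 2-(4-methylpiperazin-1-yl)ethyl group without the methylsulfonyl, would help to separate these parts, and how either behaves in this assay remains open.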